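Removing the aromatic nitrogen substituent: notes toward compound 4

The source may report more compounds than this note shows. Statements on the series, on what has been measured and on what is new or still open speak of the compounds shown alone.

Three members of the series have numbers in a functional assay on M14 cells (Homo sapiens) for cytotoxicity, read by MTT assay, with a stated time of 72 h; a lower number here means a stronger inhibitor, a higher number a weaker inhibitor. Compound 1 `CC(=O)n1cc(/C=C(/C(=O)O)c2ccccc2)c2cc(OCc3ccccc3)ccc21` carries an acetyl group on the aromatic nitrogen; in this assay compound 1 gives only a limit, > 100000 nM. Compound 2 `COc1ccc(/C(=C\c2c[nH]c3ccc(OCc4ccccc4)cc23)C(=O)O)cc1` has a free aromatic nitrogen and a methoxy group on the phenyl ring; in this assay compound 2 gives 58400 nM. Compound 3 `COc1ccc(Cn2cc(/C=C(/C(=O)O)c3ccccc3)c3cc(OCc4ccccc4)ccc32)cc1` carries a 4-methoxybenzyl group on the aromatic nitrogen; in this assay compound 3 gives 64500 nM, the highest of the two numbers, though its gap to compound 2 lies within the scatter.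

Among the compounds with values here, the only measured step at the aromatic nitrogen is an at least 1.5-fold lower number from compound 1 to compound 3 (0.19 log units; that floor lies within the scatter), and because the limit of > 100000 nM in this assay, at which 1 of the 3 values shown sits, holds for compound 1 the size of that step is known only as a floor.

Compound 4 `O=C(O)/C(=C/c1c[nH]c2ccc(OCc3ccccc3)cc12)c1ccccc1` differs from compound 3 by hydrogen in place of 4-methoxybenzyl on an aromatic nitrogen. Compound 2 and compound 4 share the free aromatic nitrogen but differ elsewhere, so their values are only a side reference. Nothing measured points to a step beyond the scatter; the expectation for compound 4 in this assay is 55000 nM, between 20000 nM and 150000 nM, which means a step of a 1.2-fold lower number from compound 3 to compound 4 (0.07 log units; within the scatter) that is expected to stay within the scatter.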

Compound 4, half-maximal inhibitory concentration: 95200 nM
For compound 4 the middle estimate is 1.7-fold (0.24 log units) below the measured one; the measured number falls inside the stated range.
By their numbers in this assay, from the lowest: compounds 2, 3 and 4 (each within the scatter of the next). At a limit, above all of these: compound 1.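

At the aromatic nitrogen, hydrogen in place of 4-methoxybenzyl gives a 1.5-fold higher number from compound 3 to compound 4 (0.17 log units; within the scatter) in this assay, so this position now has a direct comparison between a free nitrogen and a benzyl-type substituent, and the two are not told apart in this assay. Hydrogen in place of acetyl at the same nitrogen gives an at least 1.0-fold lower number from compound 1 to compound 4 (0.02 log units; that floor lies within the scatter), a step that stands only as a floor because one end of it is a limit: the limit of > 100000 nM in this assay, at which 1 of the 4 values shown sits. The free nitrogen also opens a comparison on the phenyl ring, where hydrogen in place of methoxy on an aromatic carbon gives a 1.6-fold higher number from compound 2 to compound 4 (0.21 log units; within the scatter), so neither single change shown here separates its pair of compounds beyond the scatter.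

The compounds shown leave open whether any substituent on the aromatic nitrogen, such as a simple methyl or a chain ending in an amine, would give a step beyond the scatter in this assay. They also leave open whether a change elsewhere on the shared core, such as a primary amide or a methyl ester in place of the carboxylic acid, would do so.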